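The source may report more compounds than this note shows. Statements on the series, on what has been measured and on what is new or still open speak of the compounds shown alone.

Compound 1 `O=C(O)/C(S)=C/c1c[nH]c2c(F)cccc12` is the starting point. In an assay on isolated protein for inhibition of Calpain-1 catalytic subunit (Sus scrofa), read by FRET (on this read-out higher numbers stand for weaker inhibition and lower numbers for stronger inhibition), compound 1 gives 120 nM, the lowest of the three numbers recorded. Compound 2 `O=C(O)/C(S)=C/c1cccc(Br)c1` gives 4000 nM in this assay, a higher number that lies well beyond the usual scatter, and compound 3 `O=C(O)/C(S)=C/c1ccccc1I` gives 29600 nM, higher still. Compound 1 thus stands as the strongest inhibitor of the three, with compound 2 its nearest neighbour and compound 3 the furthest away.

Compound 4 `O=C(O)/C(S)=C/c1c[nH]c2c(Cl)cccc12` is not yet measured. It keeps the whole core of compound 1 and differs in one place only: chloro in place of fluoro on an aromatic carbon. Among the compounds with values here, no pair among the measured compounds differs by a single change of this kind, so there is no measured step to lean on. Exchanging one halogen for the next larger one at the same aromatic carbon is generally a modest change, so the expectation is a small step in either direction, or none beyond the scatter, from compound 1 to compound 4 in this assay, namely a 1.3-fold higher number from compound 1 to compound 4 (0.10 log units; within the scatter). Compound 4 is therefore estimated at 150 nM, with a plausible range from 50 nM to 450 nM.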

Compound 4, half-maximal inhibitory concentration: 10 nM
The estimate for compound 4 lay 15-fold (1.18 log units) above the measured number; the measured number lies below the stated range.
By their numbers in this assay, from the lowest: compound 4; then compound 1; then compound 2; then compound 3.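

In this assay, within the data shown here, exchanging fluoro for chloro on this aromatic carbon gives a 12-fold lower number from compound 1 to compound 4 (1.08 log units; beyond the scatter) and so marks the largest single-place change seen so far, since no earlier pair of compounds differed in one place only. This position is therefore far from indifferent to which halogen it carries: one heavy atom is exchanged, with no ring, hydrogen-bond donor, hydrogen-bond acceptor or net charge entering or leaving, and inhibition still becomes clearly stronger. Nothing measured here explains why this one exchange matters so much. Going by these compounds, it remains open how this same carbon would respond to a methyl, a methoxy or a nitrile group, or to no substituent at all. On these data alone, it is also open whether chloro would bring a similar change at other carbons of this ring.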